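Swapping the cyclobutyl amide side chain of compound 1

The compounds below may be only part of what the source reports. "The series", "measured", "known", "first", "only" and "open" are said of these compounds alone.

Measured in a functional assay on HepG2 cells (Homo sapiens) for inhibition, read by MTT assay, with a stated time of 120 h; on this read-out higher numbers stand for weaker inhibition and lower numbers for stronger inhibition:
compound 1 `O=C(/C=C/c1ccc(NC(=O)Nc2ccc(Cl)c(C(F)(F)F)c2)cc1)NC1CCC1`: 7510 nM
compound 2 `CC(NC(=O)/C=C/c1ccc(NC(=O)Nc2ccc(Cl)c(C(F)(F)F)c2)cc1)c1ccccc1`: 12200 nM

Of these two numbers, compound 1 gives the lower, but the gap to compound 2 lies within the scatter, so the pair cannot be ranked. Compound 3 `CNC(=O)/C(C)=C/c1ccc(NC(=O)Nc2ccc(Cl)c(C(F)(F)F)c2)cc1` has not yet been measured. It differs from compound 1 as follows: 2-(methylcarbamoyl)prop-1-en-1-yl in place of 2-(cyclobutylcarbamoyl)ethenyl on an aromatic carbon. In short, 2-(methylcarbamoyl)prop-1-en-1-yl stands in place of 2-(cyclobutylcarbamoyl)ethenyl on an aromatic carbon. For the measured compounds named here, the only measured step with a bearing on this is a 1.6-fold higher number from compound 1 to compound 2 (0.21 log units; within the scatter), with 1-phenylethyl in place of cyclobutyl on an amide-type nitrogen. Going by the values given here, no measured compound carries the entering group, so part of the change remains untested. In this assay, no step beyond the scatter is therefore expected, and the estimated step is a 1.3-fold higher number from compound 1 to compound 3 (0.10 log units; within the scatter). For compound 3 the estimated value is 9500 nM, with an expected range from 3500 nM to 26000 nM.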

Compound 3, half-maximal inhibitory concentration: 44300 nM
Estimate against measurement, compound 3: 4.7-fold (0.67 log units) below; measured number outside the range, above it.
By their numbers in this assay, from the lowest: compounds 1 and 2 (each within the scatter of the next); then compound 3.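

In this assay, this position on the aromatic carbon proves more sensitive than the amide nitrogen alone had suggested: the change there gives a 5.9-fold higher number from compound 1 to compound 3 (0.77 log units; beyond the scatter), whereas replacing only the cyclobutyl group gave a 1.6-fold higher number from compound 1 to compound 2 (0.21 log units; within the scatter). Both groups keep the same counts of hydrogen-bond donors, hydrogen-bond acceptors and double bonds outside aromatic rings, while the four-membered ring is lost and the chain changes from ethenyl to prop-1-en-1-yl, so the step belongs to the replacement as a whole and not to either part of it. Nothing measured here accounts for the weaker inhibition. On these data alone, how the step divides between those parts remains open. So does the reading in this assay of a carboxylic acid or an amine in place of the methylcarbamoyl part.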